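The source may report more compounds than this note shows. Statements on the series, on what has been measured and on what is new or still open speak of the compounds shown alone.

In an ADME assay on MDBK cells (Bos taurus) for cytotoxicity, read by MTT assay (a lower number here means that less compound is tolerated, a higher number that more compound is tolerated), compound 1 (`OC[C@@H]1[C@@H](O)[C@H](O)[C@@H](O)CN1CCCCCCOc1cc(F)ccc1F`) gives > 500000 nM as a limit. Compound 2 (`COc1ccc(OCCCCCCN2C[C@H](O)[C@@H](O)[C@H](O)[C@H]2CO)cc1`) gives > 500000 nM as a limit too. Both sit at the limit of > 500000 nM in this assay, at which 2 of the 3 values shown sit, and no number is known for either. Compound 3 (`OC[C@@H]1[C@@H](O)[C@H](O)[C@@H](O)CN1CCCCCCOc1cc(Cl)ccc1Cl`) at 320000 nM holds the only number shown. Compound 4 (`CC1CC(OCCCCCCN2C[C@H](O)[C@@H](O)[C@H](O)[C@H]2CO)CC(C)(C)C1`) differs from it by 3,3,5-trimethylcyclohexyl in place of 2,5-dichlorophenyl on an oxygen on a saturated carbon with 3,3,5-trimethylcyclohexyl entering where 2,5-dichlorophenyl leaves. The measured steps bearing on this are an at least 1.5-fold lower number from compound 1 to compound 3 (0.19 log units; that floor lies within the scatter) and an at least 1.5-fold lower number from compound 2 to compound 3 (0.19 log units; that floor lies within the scatter) and neither involves the entering group. A small move to a lower number is therefore expected, probably not far beyond the scatter. The estimated step is a 1.6-fold lower number from compound 3 to compound 4 (0.20 log units; within the scatter) in this assay with wide uncertainty. For compound 4 the expected value is 200000 nM within a range of 70000 nM to 500000 nM as estimated here.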

Compound 4, half-maximal cytotoxic concentration: 250000 nM
Compound 4: the middle estimate sits 1.3-fold (0.10 log units) below what was measured, and the stated range covers the measured number.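

Putting 3,3,5-trimethylcyclohexyl, a non-aromatic ring of carbon only, in place of 2,5-dichlorophenyl gives a 1.3-fold lower number from compound 3 to compound 4 (0.11 log units; within the scatter) in this assay, so on this oxygen the aromatic ring can be exchanged without a change that can be read. Set against the other two compounds, the new group gives an at least 2.0-fold lower number from compound 2 to compound 4 (0.30 log units; that floor lies within the scatter) and an at least 2.0-fold lower number from compound 1 to compound 4 (0.30 log units; that floor lies within the scatter). Both steps are only floors, and they rest on a limit rather than a number: the limit of > 500000 nM in this assay, at which 2 of the 4 values shown sit.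

The compounds shown leave open how far compound 1 and compound 2 truly lie from compound 4. They also leave open whether an amine or a carboxylic acid at this place would move the number beyond the scatter.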